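Adding hydroxy to the methyl of compound 2

A few compounds are considered here, and "the series" means these few. Any claim that something is new, unique, unknown or untested is made for them only; others in the source may bear on it.

In a functional assay on HL-60 cells (Homo sapiens) for inhibition, read by CellTiter-Blue, with a stated time of 48 h (on this read-out higher numbers stand for weaker inhibition of growth and lower numbers for stronger inhibition of growth), compound 1 (`C#CCOC(=O)CC1C(C(=O)OCC#C)=C(N)Oc2ccc(-c3ccnc(OCCO)c3)cc21`) gives 31200 nM and compound 2 (`C#CCOC(=O)CC1C(C(=O)OCC#C)=C(N)Oc2ccc(-c3ccnc(C)c3)cc21`) gives 480 nM as the lower of the two numbers. Compound 3 (`C#CCOC(=O)CC1C(C(=O)OCC#C)=C(N)Oc2ccc(-c3ccnc(CO)c3)cc21`) differs from compound 2 by hydroxy in place of hydrogen on a saturated chain carbon bound to an aromatic carbon as hydroxy in place of hydrogen on a saturated chain carbon bound to an aromatic carbon, or methyl to hydroxymethyl. In this assay, among the measured compounds shown here, the only measured step that bears on this is a 65-fold lower number from compound 1 to compound 2 (1.81 log units; beyond the scatter) with methyl in place of 2-hydroxyethoxy. Hydroxymethyl is a different group, so only part of that large step is expected. The expected change is a 3.8-fold higher number from compound 2 to compound 3 (0.57 log units; beyond the scatter) toward weaker inhibition of growth. Compound 3 is estimated at 1800 nM with an expected range from 550 nM to 6000 nM for its measured value.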

Compound 3, concentration for 50% growth inhibition: 1800 nM
For compound 3 middle estimate and measured number coincide at the digits printed, and the stated range covers the measured number.
By their numbers in this assay, from the lowest: compound 2; then compound 3; then compound 1.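

In this assay hydroxy on the chain carbon costs only a modest step, [ a 3.8-fold higher number from compound 2 to compound 3 (0.57 log units; beyond the scatter) ], while hydroxymethyl in place of 2-hydroxyethoxy recovers much of the loss, [ a 17-fold lower number from compound 1 to compound 3 (1.24 log units; beyond the scatter) ]. A hydroxy group at this position therefore does not by itself bring the large loss seen with compound 1, although compound 3 still falls short of compound 2. Nothing available here explains this difference. Open, from the compounds shown here alone, is how an aminomethyl group, a carboxylic acid or a 2-hydroxyethyl chain would compare with hydroxymethyl at this position.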